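Swapping 4-methylphenyl for pyridin-3-yl in compound 3

A few compounds are considered here, and "the series" means these few. Any claim that something is new, unique, unknown or untested is made for them only; others in the source may bear on it.

Compound 1 `Cc1ccsc1-c1cc(-c2ccco2)cc(-c2ccc(Cl)cc2)n1`: 24500 nM
Compound 2 `Cc1ccsc1-c1cc(-c2ccoc2)cc(-c2ccc(Cl)cc2)n1`: 17400 nM
Compound 3 `Cc1ccc(-c2cc(-c3ccoc3)cc(-c3ccc(Cl)s3)n2)cc1`: 28700 nM

All three values come from a functional assay on HeLa cells (Homo sapiens) for cytotoxicity, read by ELISA, with a stated time of 4 days; a higher number here means a weaker inhibitor, a lower number a stronger inhibitor. Compound 3, at 28700 nM, lies within the scatter of both compound 1 and compound 2, so the three cannot be put in order.

The next compound is compound 4 `Clc1ccc(-c2cc(-c3ccoc3)cc(-c3cccnc3)n2)s1`, which has pyridin-3-yl in place of 4-methylphenyl on an aromatic carbon. The counted difference from compound 3 is pyridin-3-yl in place of 4-methylphenyl on an aromatic carbon.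

For the measured compounds named here, only one measured step is available: a 1.4-fold lower number from compound 1 to compound 2 (0.15 log units; within the scatter). It exchanges furan-2-yl for furan-3-yl, a different group from the one changing here, and it stays within the scatter. Going by the values given here, no measured compound shows what pyridin-3-yl does at this place, so the evidence is indirect and the range must be wide.

The expected step in this assay is a 1.1-fold lower number from compound 3 to compound 4 (0.04 log units; within the scatter), which is estimated to stay within the scatter, with no direction favoured. For compound 4 the estimated value is 26000 nM, with an expected range from 11000 nM to 60000 nM.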

Compound 4, half-maximal inhibitory concentration: 20000 nM
For compound 4 the middle estimate is 1.3-fold (0.11 log units) above the measured one; measured number inside the range.
By their numbers in this assay, from the lowest: compounds 2, 4, 1 and 3 (each within the scatter of the next).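

In this assay, putting pyridin-3-yl in place of 4-methylphenyl gives a 1.4-fold lower number from compound 3 to compound 4 (0.16 log units; within the scatter). For the compounds shown here, this is the first measured step at this place on the shared core, since the only earlier step exchanged furan-2-yl for furan-3-yl at a different place. It shows that a six-membered aromatic ring with one nitrogen and one hydrogen-bond acceptor can replace the all-carbon ring without a difference that stands out from the scatter, and no measurement here offers an explanation for this result.

The compounds shown leave open whether the position of the ring nitrogen matters, as pyridin-2-yl and pyridin-4-yl do not appear among them. They also do not tell what a group other than an aromatic ring, such as an amine or a carboxylic acid, would do at this place.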